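The source may hold more compounds than are shown below. What is called first, only, known or untested is meant among the compounds shown, and "the series" means these compounds.

Measured compounds:
- compound 1 `Cn1cccc1-c1ccccc1NCC1=NCCN1`: 103%
- compound 2 `CCCn1nccc1-c1ccccc1NCC1=NCCN1`: 59%

In a functional assay with Alpha-1A adrenergic receptor (Homo sapiens) as the target, read by calcium flux (a lower number here means a smaller maximal response, a higher number a larger maximal response), compound 1 reaches 103%, while compound 2 gives 59%, the lower of the two values and below compound 1 by a gap beyond the usual scatter.

Compound 3 `CC(C)n1nccc1-c1ccccc1NCC1=NCCN1` is the next variant. It differs from compound 2 by isopropyl in place of propyl on an aromatic nitrogen. Among the compounds with values here, no step between measured compounds of this kind is available, so any expectation rests on compound 2 alone.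

Compound 3 is expected to show a step of a number 1 percentage points higher from compound 2 to compound 3 (within the scatter) in this assay, that is, no change beyond the scatter. The estimate for compound 3 is 60%, with a range from 35% to 85%.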

Compound 3, largest response reached (reported as maximal response), in percent of the reference or control that the assay uses: 0%
Estimate against measurement, compound 3: 60 percentage points above; measured number outside the range, below it.
By their numbers in this assay, from the lowest: compound 3; then compound 2; then compound 1.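

In this assay, isopropyl in place of propyl on the aromatic nitrogen shows a number 59 percentage points lower from compound 2 to compound 3 (beyond the scatter), with the heavy atom count, carbon count and net charge unchanged. Within the data shown here, the response at this position therefore depends on how the same 3 carbons are joined, not only on how many there are, which the earlier compounds could not show. Nothing available gives a reason for this step. Still open, on these data alone, is how an ethyl group, a butyl chain or a cyclopropyl ring on this nitrogen would behave, and whether any branched group here keeps a response.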